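Benzylamino Replacing Trifluoromethyl on a Nitroaryl Piperazine

The source may hold more compounds than are shown below. What is called first, only, known or untested is meant among the compounds shown, and "the series" means these compounds.

Of the compounds shown here, two sharing one core have been measured in an assay on isolated protein for inhibition of NAD-dependent protein deacylase sirtuin-6 (Homo sapiens); a higher number here means a weaker inhibitor, a lower number a stronger inhibitor. Compound 1 `CN1CCN(c2ccc([N+](=O)[O-])c(O)c2)CC1` gives 11000 nM, and compound 2 `CN1CCN(c2ccc([N+](=O)[O-])c(C(F)(F)F)c2)CC1` gives 21100 nM. Within the data shown here, the single step between them, a 1.9-fold higher number from compound 1 to compound 2 (0.28 log units; within the scatter), is the one in which a trifluoromethyl takes the place of a hydroxy on an aromatic carbon. The two numbers lie within the scatter of each other, that of compound 2 being nominally the larger, so neither compound can be called the stronger inhibitor.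

Compound 3 `CN1CCN(c2ccc([N+](=O)[O-])c(NCc3ccccc3)c2)CC1` remains to be measured. Its change from compound 2 is benzylamino in place of trifluoromethyl on an aromatic carbon. Among the measured compounds shown here, no measured step covers a benzylamino entering at this carbon; the only step known stayed within the scatter, so nothing in these data points to a large movement in this assay in either direction. Compound 3 is therefore estimated at about 12000 nM, with a range of 4000 nM to 40000 nM. The expected step is a 1.8-fold lower number from compound 2 to compound 3 (0.25 log units; within the scatter).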

Compound 3, half-maximal inhibitory concentration: 12500 nM
Beside the measured number, compound 3's estimate is 1.0-fold (0.02 log units) below it, within the range that was stated.
By their numbers in this assay, from the lowest: compounds 1, 3 and 2 (each within the scatter of the next).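

In this assay, benzylamino, with 8 heavy atoms and a six-membered aromatic ring, replaces trifluoromethyl on the aromatic carbon ortho to a nitro group and gives a 1.7-fold lower number from compound 2 to compound 3 (0.23 log units; within the scatter) without a step beyond the scatter. Set against hydroxy at the same carbon, benzylamino gives a 1.1-fold higher number from compound 1 to compound 3 (0.06 log units; within the scatter), so among these three groups the position shows no difference that can be read, even with a ring and a much larger group entering there. Nothing available accounts for how close these numbers stay.

On these data alone, whether a plain amine, a carboxylic acid or a longer chain ending in the same aromatic ring would move the number beyond the scatter at this carbon stays open. So does the effect of a nitrile in place of the nitro group.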